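Pyrazinyl Amide Replaced by a Pyridinylmethyl Amide

A few compounds are considered here, and "the series" means these few. Any claim that something is new, unique, unknown or untested is made for them only; others in the source may bear on it.

For the measured compounds named here, compound 2 `O=C(Nc1cnccn1)c1c(O)c2cccnc2n(-c2ccccc2)c1=O` stands highest of the two numbers measured so far in a functional assay on the whole organism for inhibition, with Rattus norvegicus as the target, read by paw edema, at a dose of 100 mg/kg by the oral route (a lower number here means less inhibition, a higher number more inhibition at the dose given (going by the name of the read-out)), where compound 2 gives 29.6%. Compound 1 `O=C(NN1CCOCC1)c1c(O)c2cccnc2n(-c2ccccc2)c1=O` gives -8.5% in this assay. Going by the values given here, the only measured step, a number 38.1 percentage points higher from compound 1 to compound 2 (beyond the scatter), lies beyond the scatter. Compound 3 `O=C(NCc1cccnc1)c1c(O)c2cccnc2n(-c2ccccc2)c1=O` differs from compound 2 by (pyridin-3-yl)methyl in place of pyrazin-2-yl on an amide-type nitrogen. No measured step covers this change itself; the single step shown concerns another group entering the same amide-type nitrogen, so the direction is uncertain. The step of a number 11.6 percentage points lower from compound 2 to compound 3 (beyond the scatter) is expected to be small and downward. Compound 3 is expected to give about 18% in this assay, within -5% to 40%.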

Compound 3, a percentage reported as inhibition, in the whole organism at one dose (the size of the read-out at that dose, not a potency): 25.5%
Beside the measured number, compound 3's estimate is 7.5 percentage points below it; the measured number falls inside the stated range.
By their numbers in this assay, from the lowest: compound 1; then compounds 3 and 2 (each within the scatter of the next).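

On the amide-type nitrogen, (pyridin-3-yl)methyl and pyrazin-2-yl cannot be told apart in this assay, with a number 4.1 percentage points lower from compound 2 to compound 3 (within the scatter) as their step. The advantage over morpholin-4-yl therefore holds for two different aromatic groups, the second step being a number 34 percentage points higher from compound 1 to compound 3 (beyond the scatter) and each group carrying a six-membered aromatic ring. Nothing available explains these numbers.

On these data alone, whether a plain phenyl ring or an open ethyl chain would reach the same level stays open. So does the effect of a longer chain leading to the pyridin-3-yl ring.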